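A few compounds are considered here, and "the series" means these few. Any claim that something is new, unique, unknown or untested is made for them only; others in the source may bear on it.

Within the data shown here, compound 1, `CCCc1nc(Br)c2c(Br)nnc(O)n12`, is one of three compounds measured in a functional assay for inhibition, with Homo sapiens as the target; on this read-out higher numbers stand for weaker inhibition and lower numbers for stronger inhibition. In this assay compound 1 gives 48000 nM. Compound 3, `CCCc1nc(Br)c2cnnc(O)n12`, differs from compound 1 by hydrogen in place of bromo on an aromatic carbon. In this assay compound 3 reaches only the limit of the assay, > 48000 nM. The step of a number no lower from compound 1 to compound 3 (the limit leaves the size open) therefore cannot be sized, and two of the three values sit at the same limit, (the limit of > 48000 nM in this assay, at which 2 of the 3 values shown sit). Compound 2, `C=CCn1nc(Br)c2c(Br)nc(CCC)n2c1=O`, has a different core; the difference between the two cores is not broken down here. In this assay compound 2 also gives only a limit, > 48000 nM. Compound 4, `C=CCn1ncc2c(Br)nc(CCC)n2c1=O`, has not been measured; it differs from compound 2 by hydrogen in place of bromo on an aromatic carbon, the same kind of change as from compound 1 to compound 3, though here the carbon is also meta to an allyl group and para to a group of one heavy atom rather than para to a hydroxy group. Compound 2 already sits at the limit > 48000 nM. On the step of a number no lower from compound 1 to compound 3 (the limit leaves the size open), which gave no lower value, rests the expected step that the limit leaves unreadable from compound 2 to compound 4, small or none. Compound 4 is therefore expected to give 70000 nM, between 40000 nM and 150000 nM.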

Compound 4, half-maximal inhibitory concentration: > 48000 nM
Compound 4: a limit, no number; the forecaster's own chance of this, stated with the estimate: 85%; the middle value does not contradict the limit.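

In this assay compound 4 gives > 48000 nM, which is a limit and not a number. Compound 2 also stands at a limit, so no step can be read between compound 2 and compound 4. The compounds shown leave open whether hydrogen in place of bromo changes inhibition on the core of compound 2, and most values share one ceiling: the limit of > 48000 nM in this assay, at which 3 of the 4 values shown sit.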